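Replacing a sulfur-linked chain with an oxygen-linked one

This account rests on a few compounds, and the source may have more. Where it says the series, first, only, none or still open, it means among the compounds named here.

Compound 1, `CC(C)CSc1nc(N)nc2c1ncn2/C=C1/CC1(CO)CO`, in an ADME assay on HFF cells (Homo sapiens) for cytotoxicity, with a stated time of 8 days (a higher number here means that more compound is tolerated, a lower number that less compound is tolerated), gives > 300000 nM, which is a limit of the assay rather than a number.
Compound 2, `CN(C)c1nc(N)nc2c1ncn2/C=C1/CC1(CO)CO`, in this assay gives > 300000 nM, again a limit.
Compound 3, `Nc1nc(N2CCCC2)c2ncn(/C=C3/CC3(CO)CO)c2n1`, in this assay gives > 300000 nM, again a limit.

Compound 1 therefore stands at the top edge of what this assay can report, and so do the other two: the limit of > 300000 nM in this assay, at which 3 of the 3 values shown sit. Every value is a limit, and the steps among them cannot be sized: a step that the two limits leave unreadable from compound 1 to compound 2, a step that the two limits leave unreadable from compound 1 to compound 3 and a step that the two limits leave unreadable from compound 2 to compound 3 are all unreadable. What they do show is that exchanging the side group on the shared core, among these three variants, never brought cytotoxicity into the measurable range.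

Compound 4, `CCCCOc1nc(N)nc2c1ncn2/C=C1/CC1(CO)CO`, differs from compound 1 in one place: butoxy in place of isobutylsulfanyl on an aromatic carbon. Going by the values given here, no measured step addresses this particular exchange, and the steps that exist give no size to work with. Among the compounds with values here, the only guidance is that three different side groups at this position all left this assay at its limit. Compound 4 is accordingly expected to behave the same way, with an estimate of 300000 nM and a plausible range from 100000 nM to 900000 nM. The expected step of a number no higher from compound 1 to compound 4 (the limit leaves the size open) is thus none beyond the usual scatter, with the assay most likely reporting a limit once more.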

Compound 4, half-maximal cytotoxic concentration: > 300000 nM
Compound 4: no number, only a limit; the forecaster's own chance of this, stated with the estimate: 85%; the middle value sits exactly at the limit.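

In this assay, going by these compounds alone, compound 4 gives > 300000 nM, again a limit and not a number, so no step between compound 4 and compound 1, compound 2 or compound 3 can be read. All four compounds sit at the same edge: the limit of > 300000 nM in this assay, at which 4 of the 4 values shown sit. The compounds shown leave open whether any side group at this place on the shared core would bring cytotoxicity into the measurable range.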